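A few compounds are considered here, and "the series" means these few. Any claim that something is new, unique, unknown or untested is made for them only; others in the source may bear on it.

Of the compounds shown here, three built on one shared core have been tested in an in vitro functional assay on HEK285-7 cells for antagonist activity at prostaglandin D2 receptor 2 (Homo sapiens), read by BRET and beta-arrestin recruitment; on this read-out higher numbers stand for weaker inhibition and lower numbers for stronger inhibition. Compound 1, `O=C(O)Cc1sc(CSc2ccccc2)nc1-c1ccc(Cl)cc1`, gives 450 nM. Compound 2, `COc1ccc(C(c2ccccc2)c2nc(-c3ccc(Cl)cc3)c(CC(=O)O)s2)cc1`, gives 76 nM. Compound 3, `N#Cc1cc(-c2nc(C(c3ccc(F)cc3)c3ccc(F)cc3)sc2CC(=O)O)ccc1F`, gives 520 nM. The number for compound 3 is the highest of the three, yet it lies within the usual scatter of compound 1, so those two cannot be told apart on these data; only compound 2 is clearly separated from compound 3, with a lower number that means stronger inhibition.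

Compound 4, `O=C(O)Cc1sc(C(c2ccc(F)cc2)c2ccc(F)cc2)nc1-c1cc(F)nc(F)c1`, has not yet been measured. It differs from compound 3 in one place: 2,6-difluoropyridin-4-yl in place of 3-cyano-4-fluorophenyl on an aromatic carbon. Among the compounds with values here, no two measured compounds differ in a single place, so no measured step guides this change. Within the data shown here, the only anchor is the number for compound 3, and from there a small step in this assay is expected, either toward a somewhat higher number or none beyond the scatter. Compound 4 is estimated at 650 nM, with a range from 220 nM to 1900 nM. This estimate corresponds to an expected step of a 1.3-fold higher number from compound 3 to compound 4 (0.10 log units; within the scatter).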

Compound 4, half-maximal inhibitory concentration: 110 nM
Estimate against measurement, compound 4: 5.9-fold (0.77 log units) above; measured number below the stated range.
By their numbers in this assay, from the lowest: compounds 2 and 4 (each within the scatter of the next); then compounds 1 and 3 (each within the scatter of the next).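

In this assay, within the data shown here, putting 2,6-difluoropyridin-4-yl in place of 3-cyano-4-fluorophenyl gives a 4.7-fold lower number from compound 3 to compound 4 (0.67 log units; beyond the scatter) and so a step beyond the scatter, the first comparison here in which only one place differs. It shows that the aromatic carbon next to the ring nitrogen is not indifferent to the ring it carries: with the rest of compound 3 unchanged, this swap alone moves the number toward stronger inhibition. No measurement at hand explains this step.

The swap changes several things at once: the nitrile leaves, a ring nitrogen enters and one fluorine becomes two, and the compounds shown do not separate these. On these data alone, whether plain phenyl, 2-fluoropyridin-4-yl or a pyridine ring bearing an amine would move the number the same way at this position remains open.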